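Estimating compound 3 from two measured neighbours

The source may hold more compounds than are shown below. What is called first, only, known or untested is meant among the compounds shown, and "the series" means these compounds.

Compound 1 `CC(=O)NCC(=O)Nc1ccc(Cl)cc1C(=O)c1ccccc1` gives 37 mg/kg
Compound 2 `CN1CCN(CC(=O)NCC(=O)N(C)c2ccc(Cl)cc2C(=O)c2ccccc2Cl)CC1` gives 59 mg/kg

In a functional assay on the whole organism for antagonist activity, with Mus musculus as the target (a lower number here means that less compound is needed, a higher number that more compound is needed for the effect), compound 2 stands at 59 mg/kg and so lies within the usual scatter of compound 1 at 37 mg/kg with neither number set apart from the other. Compound 3 `CC(C)C(=O)NCC(=O)N(C)c1ccc(Cl)cc1C(=O)c1ccccc1Cl` keeps everything in compound 2 except one group: it carries isopropyl in place of (4-methylpiperazin-1-yl)methyl on a carbonyl carbon and nothing else changes. Within the data shown here, no measured pair shows what this swap alone does. Among the measured compounds shown here, the only guide is how closely compound 1 at 37 mg/kg and compound 2 at 59 mg/kg agree despite their different structures. The step expected in this assay is a 1.3-fold lower number from compound 2 to compound 3 (0.12 log units; within the scatter) and stays within the scatter, with no firm direction. For compound 3 the estimated value is 45 mg/kg with a range from 15 mg/kg to 130 mg/kg expected.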

Compound 3, dose for half-maximal effect: 6 mg/kg
Compound 3: middle estimate off by 7.5-fold (0.88 log units), on the high side, and the stated range ends above it.
By their numbers in this assay, from the lowest: compound 3; then compounds 1 and 2 (each within the scatter of the next).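

In this assay, among these compounds, putting isopropyl in place of (4-methylpiperazin-1-yl)methyl on a carbonyl carbon brings a 9.8-fold lower number from compound 2 to compound 3 (0.99 log units; beyond the scatter) and so shows that the group at this place can change the dose needed, which the earlier compounds, differing in more than one place, could not show. The change removes a six-membered non-aromatic ring with two nitrogens and enters a smaller group of three carbons with no ring, and this single step cannot say which of these differences counts. Nothing measured here explains the size of the step.

Still open, as far as these compounds go, is whether a cyclohexyl ring, which keeps a ring but has no nitrogen, would behave more like isopropyl or like the group it replaced. A dimethylaminomethyl group, with a nitrogen but no ring, would pose the same question from the other side.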